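This account rests on a few compounds, and the source may have more. Where it says the series, first, only, none or still open, it means among the compounds named here.

Compound 2 `COC1Cc2c(csc2-c2ccccc2)C2(CCN(Cc3ccccc3)CC2)O1` stands at the lowest number of the three compounds measured in an assay on membranes from brain for displacement of a labelled ligand from Sigma non-opioid intracellular receptor 1 (Cavia porcellus), read by scintillation counting, with a stated time of 120 min (a lower number here means a stronger inhibitor, a higher number a weaker inhibitor), where compound 2 gives 1 nM. Compound 1 `c1ccc(CN2CCC3(CC2)OCCc2c3csc2-c2ccccc2)cc1` gives 4.5 nM in this assay, and the step of a 4.5-fold lower number from compound 1 to compound 2 (0.65 log units; beyond the scatter) rests on a methoxy in place of hydrogen on a saturated ring carbon. Compound 3 `COC1Cc2c(csc2-c2cccc3ccccc23)C2(CCN(Cc3ccccc3)CC2)O1` gives 5 nM in this assay, and the step of a 5.0-fold higher number from compound 2 to compound 3 (0.70 log units; beyond the scatter) rests on naphthalen-1-yl in place of phenyl on an aromatic carbon. Its nearest neighbour on the numbers is compound 1, and compound 3 lies furthest from it.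

Compound 4 `COC1Cc2c(csc2-c2ccc(-c3ccccc3)cc2)C2(CCN(Cc3ccccc3)CC2)O1` has not yet been measured. It differs from compound 2 by phenyl in place of hydrogen on an aromatic carbon. Among the measured compounds shown here, of the two measured steps, only the one to compound 3 bears on this change, as both enlarge the same aromatic group on the shared core. That step was modest and went toward a higher number, so a similar modest rise is expected here, with the number for compound 4 expected to lie somewhat above that of compound 2. The expected step is a 4.0-fold higher number from compound 2 to compound 4 (0.60 log units; beyond the scatter). The estimate for compound 4 in this assay is 4 nM, with a range from 1.2 nM to 15 nM.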

Compound 4, inhibition constant: 30 nM
Compound 4: middle estimate off by 7.5-fold (0.88 log units), on the low side; measured number outside the range, above it.
By their numbers in this assay, from the lowest: compound 2; then compounds 1 and 3 (each within the scatter of the next); then compound 4.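

Phenyl entering on an aromatic carbon, para to a large group, gives a 30-fold higher number from compound 2 to compound 4 (1.48 log units; beyond the scatter) in this assay, and this is the only step among those shown that is graded large. Adding aromatic carbon to the phenyl of compound 2 therefore does not have one uniform outcome: a 5.0-fold higher number from compound 2 to compound 3 (0.70 log units; beyond the scatter) with naphthalen-1-yl is a modest step, whereas the added phenyl of compound 4 moves the number much further in the same direction. No measurement shown accounts for the difference between these two changes.

The compounds shown leave open whether a smaller group at the same place, such as a chlorine atom, a methoxy group or a primary amine, would keep the number close to that of compound 2, and whether a carboxylic acid there would push it up as the phenyl does. They also leave open whether the phenyl would produce a step of similar size on the core of compound 1, which lacks the methoxy group, or when placed on a different carbon of the same ring.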